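A few compounds are considered here, and "the series" means these few. Any claim that something is new, unique, unknown or untested is made for them only; others in the source may bear on it.

Measured so far in a functional assay on CHO cells for antagonist activity at sphingosine 1-phosphate receptor 2 (Homo sapiens), read by GTPgammaS binding; a higher number here means a weaker inhibitor, a lower number a stronger inhibitor:
- compound 1 `C[C@@H](C(=O)O)c1nn(Cc2cn3cc(OCC4CC4)c(Cl)cc3n2)c2ccccc2c1=O` gives 253 nM
- compound 2 `CCn1nc(CC(=O)Nc2ccc(OC(F)(F)F)c(Cl)c2)c2ccccc2c1=O` gives 473 nM
- compound 3 `CCC(C(=O)O)c1nn(Cc2cn3cc(OCC4CC4)c(Cl)cc3n2)c2ccccc2c1=O` gives 43 nM

Compound 3 holds the lowest number of the three, with compound 1 nearest and compound 2 furthest. Compound 4 `CC(C)(C(=O)O)c1nn(Cc2cn3cc(OCC4CC4)c(Cl)cc3n2)c2ccccc2c1=O` keeps the core of compound 3 and changes only the acid-bearing side chain: 1-carboxy-1-methylethyl in place of 1-carboxypropyl on an aromatic carbon. For the measured compounds named here, the one step that bears on this place is a 5.9-fold lower number from compound 1 to compound 3 (0.77 log units; beyond the scatter), which shows that the shape of this chain moves the number well beyond the scatter. Going by the values given here, no measured pair tells how a branched chain of this kind behaves, so the direction is open; a modest shift toward a higher number is taken as the central guess, the range wide. The step of a 2.1-fold higher number from compound 3 to compound 4 (0.32 log units; beyond the scatter) is expected, with compound 4 estimated at 90 nM, between 25 nM and 350 nM.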

Compound 4, half-maximal inhibitory concentration: 105 nM
The estimate for compound 4 lay 1.2-fold (0.07 log units) below the measured number; the range from low to high includes it.
By their numbers in this assay, from the lowest: compound 3; then compound 4; then compounds 1 and 2 (each within the scatter of the next).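

In this assay the same atoms joined as 1-carboxy-1-methylethyl instead of 1-carboxypropyl give a 2.4-fold higher number from compound 3 to compound 4 (0.39 log units; beyond the scatter) at this position, so the way the chain is joined moves the number, not only its atom count. 1-Carboxy-1-methylethyl in place of 1-carboxyethyl gives a 2.4-fold lower number from compound 1 to compound 4 (0.38 log units; beyond the scatter) and places the branched chain between the other two chains. No evidence available here explains this order.

From the compounds shown here alone, whether a longer chain such as 1-carboxybutyl would continue this trend remains open. So does the effect of a methyl ester in place of the carboxylic acid.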